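The source may hold more compounds than are shown below. What is called first, only, known or untested is meant among the compounds shown, and "the series" means these compounds.

Of the compounds shown here, three built on one shared core have so far been tested in an ADME assay on L02 cells (Homo sapiens) for antiproliferative activity, read by MTT assay, with a stated time of 48 h (on this read-out higher numbers stand for weaker inhibition and lower numbers for stronger inhibition), and none of them has returned a number. Compound 1 `Cc1ccccc1-n1nncc1CN1C(=O)C2(C(C#N)=C(N)Oc3c2c2nc4ccccc4nc2c2ccccc32)c2ccccc21` gives > 50000 nM, which is a limit of the assay and not a value. Compound 2 `Cc1ccc(-n2nncc2CN2C(=O)C3(C(C#N)=C(N)Oc4c3c3nc5ccccc5nc3c3ccccc43)c3ccccc32)c(C)c1` gives > 50000 nM, again a limit. Compound 3 `N#CC1=C(N)Oc2c(N)cc3nc4ccccc4nc3c2C12C(=O)N(Cc1cnnn1-c1ccc([N+](=O)[O-])cc1)c1ccccc12` gives > 50000 nM, also only a limit. Among the compounds with values here, the single measured change, methyl in place of hydrogen on an aromatic carbon, is recorded as a step that the two limits leave unreadable from compound 1 to compound 2, so it yields no size at all. Compound 3 therefore stands where the other two stand, at the limit of > 50000 nM in this assay, at which 3 of the 3 values shown sit, and nothing in the data sets any of the three apart from the others.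

Compound 4 `Cc1cc(C)c(-n2nncc2CN2C(=O)C3(C(C#N)=C(N)Oc4c(N)cc5nc6ccccc6nc5c43)c3ccccc32)c(C)c1` differs from compound 3 by 2,4,6-trimethylphenyl in place of 4-nitrophenyl on an aromatic nitrogen. No measured step concerns this change, and the one step that exists is unreadable, so no direction and no size can be drawn from the shown values. On the evidence at hand, compound 4 is expected to behave like the three compounds before it and to sit at the limit rather than give a number. The step from compound 3 to compound 4 is thus estimated as a step that the limit leaves unreadable from compound 3 to compound 4. For compound 4 the estimate in this assay is 60000 nM, with a range from 30000 nM to 150000 nM.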

Compound 4, half-maximal inhibitory concentration: > 50000 nM
Compound 4: only a limit was reported; the forecaster's own chance of this, stated with the estimate: 85%; the middle value is on the limit's open side.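

Compound 4 returns only a limit, as compound 3 does, so no step can be read from compound 3 to compound 4. All the compounds shown now sit together: the limit of > 50000 nM in this assay, at which 4 of the 4 values shown sit. They leave open how far each lies past that limit in this assay and whether 2,4,6-trimethylphenyl or 4-nitrophenyl makes any difference there.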